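The source may report more compounds than this note shows. Statements on the series, on what has been measured and on what is new or still open speak of the compounds shown alone.

Measured so far in an assay on CHO cells for displacement of a labelled ligand from Alpha-1A adrenergic receptor (Homo sapiens); a higher number here means a weaker inhibitor, a lower number a stronger inhibitor:
- compound 1, `COc1cccc(OC)c1OCCNCCOc1ccccc1OCc1ccccc1`: 0.468 nM
- compound 2, `COc1cccc(OC)c1OCCNCCOc1ccccc1OCc1ccccc1C`: 1.59 nM
- compound 3, `COc1cccc(OC)c1OCCNCCOc1ccccc1OCc1ccc(C)cc1`: 2 nM

Compound 3 gives the highest of the three numbers in this assay; it sits a 1.3-fold higher number from compound 2 to compound 3 (0.10 log units; within the scatter) and a 4.3-fold higher number from compound 1 to compound 3 (0.63 log units; beyond the scatter). Compound 4, `COc1cccc(OC)c1OCCNCCOc1ccccc1OCc1cccc([N+](=O)[O-])c1`, differs from compound 3 by 3-nitrophenyl in place of 4-methylphenyl on a saturated chain carbon bound to an oxygen on an aromatic ring. Going by the values given here, no measured step exchanges a methyl for a nitro group, so the only guidance comes from the ring-substitution steps: a 3.4-fold higher number from compound 1 to compound 2 (0.53 log units; beyond the scatter), a 4.3-fold higher number from compound 1 to compound 3 (0.63 log units; beyond the scatter), and a 1.3-fold higher number from compound 2 to compound 3 (0.10 log units; within the scatter). Each added substituent on that ring raised the number modestly; moving the methyl between positions changed little. Compound 4 is therefore expected to stay near compound 3, with at most a small further rise, a 1.6-fold higher number from compound 3 to compound 4 (0.20 log units; within the scatter). The estimate for compound 4 in this assay is 3.2 nM, within 1 nM to 10 nM.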

Compound 4, inhibition constant: 0.316 nM
Estimate against measurement, compound 4: 10-fold (1.01 log units) above; the measured number lies below the stated range.
By their numbers in this assay, from the lowest: compounds 4 and 1 (each within the scatter of the next); then compounds 2 and 3 (each within the scatter of the next).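

In this assay, 3-nitrophenyl in place of 4-methylphenyl gives a 6.3-fold lower number from compound 3 to compound 4 (0.80 log units; beyond the scatter) and in place of 2-methylphenyl gives a 5.0-fold lower number from compound 2 to compound 4 (0.70 log units; beyond the scatter), so the higher numbers seen with both methyl groups do not hold for every substituent on this ring. Nitro in place of hydrogen gives a 1.5-fold lower number from compound 1 to compound 4 (0.17 log units; within the scatter), which is within the scatter, so this ring takes the nitro group with no measurable change from the unsubstituted compound 1. Whether an amine, a carboxylic acid or a methoxy group on that ring would behave like nitro or like methyl stays open, and nothing given here explains the difference between the two substituents.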